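This account rests on a few compounds, and the source may have more. Where it says the series, first, only, none or still open, it means among the compounds named here.

Measured compounds:
Compound 1 `CN(Cc1cn(C2CCCCC2OC(=O)c2ccccc2)nn1)CC1CCCCC1`: 32% in an assay on nucleic acid for inhibition of Nucleic Acid, read by fluorescence, tested at 100 uM; a lower number here means less inhibition, a higher number more inhibition at the concentration tested (going by the name of the read-out)
Compound 2 `CC(C)CCN(C)Cc1cn(CC(O)COC(=O)NCc2ccccc2)nn1`: 26%
Compound 3 `CN(Cc1cn(C2CCCCC2OC(=O)COc2ccccc2)nn1)CC1CCCCC1`: 37%

Among these three, compound 3 gives the highest number in this assay, though its lead over compound 1 stays within the scatter; only the gap to compound 2 lies beyond it. Compound 4 `CCCCN(CCCC)Cc1cn(C2CCCCC2OC(=O)COc2ccccc2)nn1` is the unmeasured partner of compound 3. The change is dibutylamino in place of (cyclohexylmethyl)(methyl)amino on a saturated chain carbon bound to an aromatic carbon.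

Going by the values given here, only one single-place step is on record, and it concerns the ester part rather than the amine: a number 5 percentage points higher from compound 1 to compound 3 (within the scatter), a change that did not move the read-out beyond the scatter. Among the compounds with values here, no measured step alters the groups on the amine nitrogen, so nothing directly tells how the swap to dibutylamino will read. Compound 2 carries a different amine and gives a lower number than compound 3, but it differs in more than one place, so its value cannot be read as a guide to this step alone.

Within the data shown here, with no relevant precedent, the step is expected to stay small. The expected step of a number 2 percentage points lower from compound 3 to compound 4 (within the scatter) would lie within the scatter. Compound 4 is therefore estimated at 35%, with a range from 22% to 48%.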

Compound 4, a percentage reported as inhibition, at one concentration (the size of the read-out at that concentration, not a potency): 26%
For compound 4 the middle estimate is 9 percentage points above the measured one; low and high end bracket the measured number.
By their numbers in this assay, from the lowest: compounds 2, 4, 1 and 3 (each within the scatter of the next, the first and the last beyond it).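

In this assay, going by these compounds alone, the swap of dibutylamino for (cyclohexylmethyl)(methyl)amino on a saturated chain carbon bound to an aromatic carbon gives a number 11 percentage points lower from compound 3 to compound 4 (beyond the scatter), the first single-place change at this amine and the first single-place step on record to go beyond the scatter, as the earlier ester change gave a number 5 percentage points higher from compound 1 to compound 3 (within the scatter). The two groups have the same count of heavy atoms and the same atoms, and what changes is the shape of the carbon framework: the six-membered non-aromatic ring leaves, and two open butyl chains enter in place of the ring-bearing group and the methyl group. Nothing available explains why this change lowers the read-out.

On these data alone, it remains open whether the loss of the ring or the change from an unequal to an equal pair of groups on the nitrogen accounts for the step, and a butyl(methyl)amino group or a piperidine ring at the same place would help to separate the two. As far as these compounds go, it also remains open whether the same amine swap would give a step of similar size with the ester carried by compound 1.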